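Imidazole biphenyl acids at bombesin receptor subtype-3: neopentyl variant

The source may report more compounds than this note shows. Statements on the series, on what has been measured and on what is new or still open speak of the compounds shown alone.

Measured so far:
compound 1 `CCCCc1cnc(CCCc2ccc(-c3ccccc3C(=O)O)cc2)[nH]1` — 5600 nM
compound 2 `O=C(O)c1ccccc1-c1ccc(CCc2ncc(CC3CCCC3)[nH]2)cc1` — 133 nM
compound 3 `CCCCc1cnc(C(CCCC)Cc2ccc(-c3ccccc3C(=O)O)cc2)[nH]1` — 2660 nM

All three share the imidazole-linked biphenyl carboxylic acid core and were run in an in vitro functional assay on cells for agonist activity at Bombesin receptor subtype-3 (Homo sapiens), read by luminescence and calcium flux; on this read-out higher numbers stand for an effect only at larger amounts of compound and lower numbers for an effect already at smaller amounts. Compound 2 gives the lowest number of the three, at 133 nM. Compound 3 sits nearest to it, and that gap lies beyond the scatter; compound 1 lies furthest off, also beyond the scatter. Compound 2 is therefore the most potent of the measured set on this read-out.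

The next compound, compound 4 `CC(C)(C)Cc1cnc(CCc2ccc(-c3ccccc3C(=O)O)cc2)[nH]1`, is not yet measured. Against compound 2 the change is tert-butyl in place of cyclopentyl on a saturated chain carbon bound to an aromatic carbon. Within the data shown here, no measured pair isolates this kind of change, so there is no directly comparable step to lean on. Among the measured compounds shown here, the only hint is that the two-carbon-linked, branched-substituent pattern of compound 2 gives the best number so far, and compound 4 keeps that linker while swapping the substituent. A small loss is expected, reading the step from compound 2 to compound 4 as a 2.6-fold higher number from compound 2 to compound 4 (0.42 log units; beyond the scatter), rather than a gain. Compound 4 is accordingly estimated at 350 nM, with a range from 120 nM to 1200 nM.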

Compound 4, half-maximal effective concentration: 106 nM
The estimate for compound 4 lay 3.3-fold (0.52 log units) above the measured number; measured number outside the range, below it.
By their numbers in this assay, from the lowest: compounds 4 and 2 (each within the scatter of the next); then compound 3; then compound 1.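

In this assay the change of cyclopentyl to tert-butyl on a saturated chain carbon bound to an aromatic carbon reads as a 1.3-fold lower number from compound 2 to compound 4 (0.10 log units; within the scatter) and leaves the two compounds indistinguishable on this read-out. Among these compounds, this is the first step with a single point of difference, and it shows that, in this pair, the five-membered non-aromatic ring of carbon is not needed to keep the number. Cyclopentylmethyl and neopentyl can therefore be treated as interchangeable at this position on the two-carbon-linked compounds shown, though nothing measured here bears on why they read alike.

From the compounds shown here alone, whether this tolerance extends to a cyclohexylmethyl or isobutyl group, or to a chain carrying an amine or a hydroxyl group, remains open. Compound 1 and compound 3 each differ from compound 2 and compound 4 in more than one place, so the contribution of the chain joining the shared core to the imidazole also remains unresolved.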